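Swapping the Aryl Group on a Thiosemicarbazone

The source may report more compounds than this note shows. Statements on the series, on what has been measured and on what is new or still open speak of the compounds shown alone.

In a functional assay on HL-60 cells (Homo sapiens) for antiproliferative activity, read by sulforhodamine B assay, with a stated time of 72 h (a lower number here means a stronger inhibitor, a higher number a weaker inhibitor), compound 1 `S=C(N/N=C/c1ccc2ccccc2n1)Nc1ccc(Br)cc1` gives 27500 nM. Compound 2 `CC(C)c1cccc(C(C)C)c1NC(=S)N/N=C/c1ccc2ccccc2n1` gives 19500 nM in this assay, and the two numbers lie within the scatter of each other, so compound 1 cannot be set apart from compound 2. Compound 3 `Fc1ccccc1NC(=S)N/N=C/c1ccc2ccccc2n1` has not been measured yet. It differs from compound 1 in one place: 2-fluorophenyl in place of 4-bromophenyl on an amide-type nitrogen. Among the measured compounds shown here, no measured pair shows what such a change does here, so the expected step of a 1.1-fold lower number from compound 1 to compound 3 (0.04 log units; within the scatter) is small, within the scatter. Compound 3 is therefore estimated at 25000 nM, with a range from 8000 nM to 80000 nM.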

Compound 3, half-maximal inhibitory concentration: > 100000 nM
Compound 3: only a limit was reported; the forecaster's own chance of this, stated with the estimate: 20%; middle value at least 4.0-fold (0.60 log units) away from the limit.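

Swapping the aryl group on this amide-type nitrogen can matter: replacing 4-bromophenyl with 2-fluorophenyl gives, in this assay, an at least 3.6-fold higher number from compound 1 to compound 3 (0.56 log units; beyond the scatter). Compound 1 and compound 2 could not be set apart, so this is the first step shown here that lies beyond the scatter. The true size of the step remains unknown, since compound 3 has only a limit of the assay: the limit of > 100000 nM in this assay, at which 1 of the 3 values shown sits.

Still open, going by these compounds, is whether the change of halogen or its place on the ring drives this step. On these data alone, how an amine or a carboxylic acid on that phenyl ring would behave also remains unknown.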